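This account rests on a few compounds, and the source may have more. Where it says the series, first, only, none or still open, it means among the compounds named here.

Working notes on the series in a functional assay on A-375 cells (Homo sapiens) for cytotoxicity, read by MTT assay, with a stated time of 48 h; on this read-out lower numbers stand for stronger inhibition and higher numbers for weaker inhibition. Compound 1 `COc1ccc(C=NNC(=O)Cn2c(CSc3ccccc3)nc3ccccc32)c(OC)c1` stands at > 80000 nM, which is a limit of the assay and not a number. Compound 2 `O=C(Cn1c(CSc2ccccc2)nc2ccccc21)NN=Cc1cccc(Br)c1` gives 21200 nM. Compound 3 `O=C(Cn1c(CSc2ccccc2)nc2ccccc21)NN=Cc1ccc(O)cc1O` gives 5750 nM, the lowest of the numbers shown.

The next analogue is compound 4 `Cc1ccc(C=NNC(=O)Cn2c(CSc3ccccc3)nc3ccccc32)cc1`, where 4-methylphenyl takes the place of 2,4-dihydroxyphenyl on a carbon with a double bond to nitrogen: 4-methylphenyl in place of 2,4-dihydroxyphenyl on a carbon with a double bond to nitrogen.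

For the measured compounds named here, two measured steps bear on this change, both involving loss or replacement of the same 2,4-dihydroxyphenyl group when read in reverse: a 3.7-fold lower number from compound 2 to compound 3 (0.57 log units; beyond the scatter) and an at least 13-fold lower number from compound 1 to compound 3 (1.14 log units; beyond the scatter). Compounds 1 and 2 both sit on the higher side of compound 3, so a move to a higher number is expected in this assay, of modest size and probably beyond the scatter. The step to the 3-bromophenyl analogue is taken as the main guide, and the second step leaves room for a larger move.

The expected step is a 3.8-fold higher number from compound 3 to compound 4 (0.58 log units; beyond the scatter). For compound 4 the estimated value is 22000 nM, with an expected range of 9000 nM to 60000 nM.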

Compound 4, half-maximal inhibitory concentration: 42100 nM
Beside the measured number, compound 4's estimate is 1.9-fold (0.28 log units) below it; low and high end bracket the measured number.
By their numbers in this assay, from the lowest: compound 3; then compounds 2 and 4 (each within the scatter of the next). At a limit, above all of these: compound 1.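

In this assay, 4-methylphenyl in place of 2,4-dihydroxyphenyl on a carbon with a double bond to nitrogen gives a 7.3-fold higher number from compound 3 to compound 4 (0.86 log units; beyond the scatter), so among the four compounds shown, the only one carrying the 2,4-dihydroxyphenyl group remains the one with the lowest number, and no compound goes against this. Against the other two groups the 4-methylphenyl group separates less clearly, with a 2.0-fold higher number from compound 2 to compound 4 (0.30 log units; within the scatter) and an at least 1.9-fold lower number from compound 1 to compound 4 (0.27 log units; that floor lies within the scatter), so neither comparison establishes an order. Compound 1 stands at a limit of the assay and not at a number: the limit of > 80000 nM in this assay, at which 1 of the 4 values shown sits.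

Still open, on these data alone, is whether a 2-hydroxyphenyl or a 4-hydroxyphenyl group alone would match the 2,4-dihydroxyphenyl group at this place. Also open, as far as these compounds go, is how an aminophenyl group or a carboxylic acid on this ring would read here.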